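Predicting metabolic stability after methylating an amide nitrogen

The source may report more compounds than this note shows. Statements on the series, on what has been measured and on what is new or still open speak of the compounds shown alone.

Compound 3 `CN(C(=O)[C@H]1CN(S(=O)(=O)c2ccccc2)C[C@@H]1NC(=O)c1cc(-c2ccccc2Cl)on1)[C@H]1CCCNC1` stands lowest of the three measured compounds in an ADME assay on cells (Hepatocyte, Rattus norvegicus) for metabolic stability (on this read-out lower numbers stand for slow clearance and higher numbers for fast clearance), where compound 3 gives 5.8 uL/min. Compound 2 `CN(C(=O)c1cc(-c2ccccc2Cl)on1)[C@H]1CN(S(=O)(=O)c2ccccc2)C[C@@H]1C(=O)N[C@H]1CCCNC1` gives 12 uL/min, and compound 1 `O=C(N[C@H]1CN(S(=O)(=O)c2ccccc2)C[C@@H]1C(=O)NC[C@@H]1CCCN1)c1cc(-c2ccccc2Cl)on1` gives 22 uL/min. The only single-step comparison shown is a 3.8-fold lower number from compound 1 to compound 3 (0.58 log units; beyond the scatter), which concerns a different part of the molecule. Compound 4 `CN(C(=O)[C@H]1CN(S(=O)(=O)c2ccccc2)C[C@@H]1N(C)C(=O)c1cc(-c2ccccc2Cl)on1)[C@H]1CCCNC1` differs from compound 3 by methyl in place of hydrogen on an amide-type nitrogen. Among the measured compounds shown here, no measured step isolates this change; compounds 1 and 2 differ at this nitrogen but also elsewhere, so their values only show that both lie above compound 3. The expected step is therefore small, a 1.2-fold higher number from compound 3 to compound 4 (0.08 log units; within the scatter), not beyond the scatter. Compound 4 is estimated at 7 uL/min, within 3 uL/min to 16 uL/min.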

Compound 4, intrinsic clearance in a liver preparation (reported as CLH), per the amount of preparation that the assay uses: 13 uL/min
Compound 4: the middle estimate sits 1.9-fold (0.27 log units) below what was measured; measured number inside the range.
By their numbers in this assay, from the lowest: compound 3; then compounds 2, 4 and 1 (each within the scatter of the next).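

In this assay, among the compounds shown here, methyl in place of hydrogen on an amide-type nitrogen gives a 2.2-fold higher number from compound 3 to compound 4 (0.35 log units; beyond the scatter) and provides the first isolated reading of this change, which lies beyond the scatter. The same replacement on the other amide-type nitrogen gives a 1.1-fold higher number from compound 2 to compound 4 (0.03 log units; within the scatter) and stays within the scatter, so the two nitrogens do not read alike in these compounds. Nothing shown accounts for either step. Going by these compounds, whether an ethyl group or a longer chain on the first nitrogen would raise the number further remains open.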